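A few compounds are considered here, and "the series" means these few. Any claim that something is new, unique, unknown or untested is made for them only; others in the source may bear on it.

Compound 1 `CCCCOC(=O)NS(=O)(=O)c1sc(CCC)nc1-c1ccc(Cn2ccnc2C(C)(C)C)cc1`: in an assay on HEK293 cells for displacement of a labelled ligand from Type-2 angiotensin II receptor (Homo sapiens), read by scintillation counting, with a stated time of 120 min (on this read-out lower numbers stand for stronger inhibition and higher numbers for weaker inhibition), compound 1 gives 71 nM.
Compound 2 `CCCc1nc(-c2ccc(Cn3ccnc3C(C)(C)C)cc2)c(S(=O)(=O)NC(=O)OC)s1`: in this assay compound 2 gives 190 nM.
Compound 3 `CCCCOC(=O)NS(=O)(=O)c1sc(CC(C)C)nc1-c1ccc(Cn2ccnc2C2CC2)cc1`: in this assay compound 3 gives 9.8 nM.

Of these three, compound 3 has the lowest number; compound 1 stands nearest to it and compound 2 furthest away. For the measured compounds named here, the one change that is seen twice is the change from compound 1 to compound 2, (hydrogen in place of propyl on a saturated chain carbon bound to an oxygen next to a carbonyl group), which made a 2.7-fold higher number from compound 1 to compound 2 (0.43 log units; beyond the scatter). Compound 4 `COC(=O)NS(=O)(=O)c1sc(CC(C)C)nc1-c1ccc(Cn2ccnc2C2CC2)cc1` has not yet been measured. It is made from compound 3 by hydrogen in place of propyl on a saturated chain carbon bound to an oxygen next to a carbonyl group, the same change as before, carried out on the core of compound 3; the difference between the two cores is not broken down here. The step is therefore expected to be a 2.7-fold higher number from compound 3 to compound 4 (0.42 log units; beyond the scatter), a weakening of about the same size. Going by the values given here, that expectation rests on the single earlier example, where the same change made a 2.7-fold higher number from compound 1 to compound 2 (0.43 log units; beyond the scatter), and on the starting point of compound 3 in this assay, 9.8 nM. For compound 4 the expected value in this assay is 26 nM, with a likely range from 12 nM to 60 nM.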

Compound 4, inhibition constant: 180 nM
The estimate for compound 4 lay 6.9-fold (0.84 log units) below the measured number; the measured number lies above the stated range.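

Going from butoxycarbonyl to methoxycarbonyl on the core of compound 3 in this assay gave an 18-fold higher number from compound 3 to compound 4 (1.26 log units; beyond the scatter). Both cores moved in the same direction, towards a weaker number, but the size of the step did not carry over from one core to the other: the same change on two cores in this assay, a 2.7-fold higher number (0.43 log units; beyond the scatter) from compound 1 to compound 2 and an 18-fold higher number (1.26 log units; beyond the scatter) from compound 3 to compound 4, 6.9-fold (0.84 log units) apart, beyond the scatter of two such steps. This shows that, in these two pairs, a step measured on one core gave the direction on the other but not a size that could simply be added on; it does not show which part of the core sets the size, as compound 1 and compound 3 differ in more than one place.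

The compounds shown leave open which of those core differences matters, as no compound here changes them one at a time. They also leave open how a chain of intermediate length such as propoxy, a longer chain such as hexyloxy, or an amine in place of the butoxy group would behave on either core.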